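The source may report more compounds than this note shows. Statements on the series, on what has been measured and on what is new or still open speak of the compounds shown alone.

Measured so far:
- Compound 1 `CC(=O)Nc1ccc(S(=O)(=O)NNc2ccc(C#N)cc2)cc1`: 5670 nM
- Compound 2 `CC(=O)Nc1ccc(S(=O)(=O)NNc2ccc(F)cc2)cc1`: 79 nM
- Compound 3 `CC(=O)Nc1ccc(S(=O)(=O)NNc2ccc(Br)cc2)cc1`: 130 nM

All three share one core and differ only in the group on the far aromatic ring. In an assay for inhibition of Indoleamine 2,3-dioxygenase 1 (Homo sapiens), read by spectrophotometry, with stated times of 1 h and 4 h (a higher number here means a weaker inhibitor, a lower number a stronger inhibitor), compound 1 gives 5670 nM, the highest number of the three. The step from cyano to fluoro, a 72-fold lower number from compound 1 to compound 2 (1.86 log units; beyond the scatter), and the step from cyano to bromo, a 44-fold lower number from compound 1 to compound 3 (1.64 log units; beyond the scatter), are both large. Between the fluoro and bromo compounds, a 1.6-fold higher number from compound 2 to compound 3 (0.22 log units; within the scatter), the difference is within the scatter, so compound 3 stands close to compound 2 and far from compound 1.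

Compound 4 `O=S(=O)(NNc1ccc(Br)cc1)c1ccccc1` arises from compound 3 by a change at the other end of the molecule: hydrogen in place of acetamido on an aromatic carbon. Among the compounds with values here, none of the measured steps touches this position, so no step bears on it directly; the measured steps all concern the group on the opposite ring. With nothing to test the change, the expectation for compound 4 is a modest rise in the number, a 2.3-fold higher number from compound 3 to compound 4 (0.36 log units; beyond the scatter), held with low confidence. Compound 4 is therefore estimated at 300 nM, within a wide range from 60 nM to 2000 nM.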

Compound 4, half-maximal inhibitory concentration: 172 nM
Compound 4: middle estimate off by 1.7-fold (0.24 log units), on the high side, within the range that was stated.
By their numbers in this assay, from the lowest: compounds 2, 3 and 4 (each within the scatter of the next, the first and the last beyond it); then compound 1.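

Within the data shown here, this is the first look at the acetamido end of the molecule. In this assay, with bromo held on the opposite ring, hydrogen in place of the whole acetamido group, hydrogen-bond donor and acceptor included, gives a step within the scatter (a 1.3-fold higher number from compound 3 to compound 4 (0.12 log units; within the scatter)), so the two compounds cannot be told apart, and the acetamido group is not needed for a number in this range. That small step contrasts with the large one seen on the opposite ring (a 44-fold lower number from compound 1 to compound 3 (1.64 log units; beyond the scatter)), and nothing available here explains the difference.

This single step leaves open whether the same exchange would be as quiet on the fluoro compound 2 or the cyano compound 1. It also leaves open how other groups at this position, such as an amine, a carboxylic acid or a longer amide chain, would read.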